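The compounds below may be only part of what the source reports. "The series", "measured", "known", "first", "only" and "open" are said of these compounds alone.

Measured so far in a functional assay on HepG2 cells (Homo sapiens) for cytotoxicity, read by MTT assay; on this read-out lower numbers stand for stronger inhibition and higher numbers for weaker inhibition:
- Compound 1 `COc1ccc(/C=C/C(=O)c2ccc(OC)c3c2OC(C)(C)C=C3)cc1OCCCN(C)C`: 5550 nM
- Compound 2 `CCC(=O)Oc1cc(/C=C/C(=O)c2ccc(OC)c3c2OC(C)(C)C=C3)ccc1OC`: 90 nM
- Compound 3 `COc1ccc(/C=C/C(=O)c2ccc(OC)c3c2OC(C)(C)C=C3)cc1OC(=O)C1CC1`: 220 nM

Compound 3 holds the middle place of these three numbers, above compound 2 and far below compound 1. Compound 4 `COc1ccc(/C=C/C(=O)c2ccc(OC)c3c2OC(C)(C)C=C3)cc1OC(=O)c1ccco1` keeps the shared core and differs from compound 3 at one place: furan-2-yl in place of cyclopropyl on a carbonyl carbon. In short, furan-2-yl stands in place of cyclopropyl on a carbonyl carbon.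

The nearest measured change sits at that same place: a 2.4-fold higher number from compound 2 to compound 3 (0.39 log units; beyond the scatter), a modest step. The two large steps, a 62-fold lower number from compound 1 to compound 2 (1.79 log units; beyond the scatter) and a 25-fold lower number from compound 1 to compound 3 (1.40 log units; beyond the scatter), replace 3-(dimethylamino)propyl on an oxygen and bear only on the need to keep a carbonyl there, which compound 4 does. Among the measured compounds shown here, no measured compound carries an aromatic ring at this place, so the direction is uncertain. In this assay, a small step at most is expected, perhaps none beyond the scatter. The estimated step is a 1.1-fold higher number from compound 3 to compound 4 (0.06 log units; within the scatter). For compound 4 the expected value is 250 nM, with an estimated range from 90 nM to 700 nM.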

Compound 4, half-maximal inhibitory concentration: 370 nM
For compound 4 the middle estimate is 1.5-fold (0.17 log units) below the measured one; the range from low to high includes it.
By their numbers in this assay, from the lowest: compound 2; then compounds 3 and 4 (each within the scatter of the next); then compound 1.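

Furan-2-yl puts an aromatic ring on this carbonyl carbon for the first time, and in this assay it cannot be told apart from cyclopropyl (a 1.7-fold higher number from compound 3 to compound 4 (0.23 log units; within the scatter)). Ethyl, by contrast, stays clearly apart from furan-2-yl (a 4.1-fold higher number from compound 2 to compound 4 (0.61 log units; beyond the scatter)), so compound 2 keeps the lowest number of the four, while the two ring-bearing compounds remain within the scatter of each other. The large gap to the 3-(dimethylamino)propyl compound also survives with this heavier group on the carbonyl (a 15-fold lower number from compound 1 to compound 4 (1.18 log units; beyond the scatter)), which extends the earlier finding to an aromatic ring.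

The data offered here give no explanation for these differences. Still open, on these data alone, is how a phenyl ring, a thiophene ring, a longer alkyl chain or a carbonyl-linked amine would read at this carbonyl carbon.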